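The source may hold more compounds than are shown below. What is called first, only, known or untested is meant among the compounds shown, and "the series" means these compounds.

The measured compounds:
Compound 1, `COC(=O)c1cccc(Cn2nc(OC)oc2=O)c1`, gives 20% in an assay on COS-7 cells for inhibition of Fatty-acid amide hydrolase 1 (Homo sapiens), read by scintillation counting, with a stated time of 10 min, tested at 10 uM; a lower number here means less inhibition, a higher number more inhibition at the concentration tested (going by the name of the read-out).
Compound 2, `COc1nn(Cc2cccc(C(F)(F)F)c2)c(=O)o1`, gives 12% in this assay.

For the measured compounds named here, compound 2 stands alongside compound 1 within the usual scatter: the only step so far, a number 8 percentage points lower from compound 1 to compound 2 (within the scatter), does not separate the two, and both numbers show only weak inhibition at the concentration tested.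

Compound 3, `COc1cccc(Cn2nc(OC)oc2=O)c1`, has not yet been measured. It differs from compound 2 in one place: methoxy in place of trifluoromethyl on an aromatic carbon.

Going by the values given here, the one measured step bears on it only loosely, since it changed the same position with a different pair of groups and stayed within the scatter. With the shared core held and both measured values small, no step beyond the scatter is expected for compound 3, and the estimated step of a number 3 percentage points higher from compound 2 to compound 3 (within the scatter) reflects that. Compound 3 is therefore expected to give about 15% in this assay, with a likely range from 0% to 35%.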

Compound 3, a percentage reported as inhibition, at one concentration (the size of the read-out at that concentration, not a potency): "not active" (no number reported)
For compound 3 the study gives words and no number; there is nothing to compare the estimate with.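

For the compounds shown here, compound 3 is reported in this assay only in words, as not active, so no step from compound 2 to compound 3 can be read. Nothing at hand explains this result. The compounds shown leave open how much methoxy in place of trifluoromethyl changes inhibition.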